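The compounds below may be only part of what the source reports. "The series", "measured", "known", "first", "only" and "open" are said of these compounds alone.

Measured so far in a functional assay on BT-549 cells (Homo sapiens) for cytotoxicity, read by sulforhodamine B assay, with a stated time of 48 h; on this read-out higher numbers stand for lower toxicity in this test and lower numbers for higher toxicity in this test:
Compound 1 `ClCc1ccccc1Cn1cnc2c(Cl)nc(Cl)nc21` gives 4160 nM.
Compound 2 `ClCc1ccccc1Cn1cnc2c(Cl)ncnc21` gives 20000 nM.
Compound 3 `ClCc1ccc(Cn2cnc3nc(Cl)nc(Cl)c32)cc1` gives 6450 nM.

Compound 1 and compound 2 differ in one place hydrogen in place of chloro on an aromatic carbon and this change gave a 4.8-fold higher number from compound 1 to compound 2 (0.68 log units; beyond the scatter). Compound 3 shares its atoms with compound 1 but joins them differently; the difference between the two cores is not broken down here. Compound 4 `ClCc1ccc(Cn2cnc3ncnc(Cl)c32)cc1` is not yet measured and differs from compound 3 by the same change (hydrogen in place of chloro on an aromatic carbon), with the place described in the same words. Because the change gave a 4.8-fold higher number from compound 1 to compound 2 (0.68 log units; beyond the scatter) on the core of compound 1, a step of similar size is expected on the core of compound 3, with the values of compound 1 and compound 3 lying close together. The expected step is a 4.7-fold higher number from compound 3 to compound 4 (0.67 log units; beyond the scatter). Compound 4 is therefore estimated at 30000 nM, likely between 12000 nM and 80000 nM.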

Compound 4, concentration lethal to 50% of the cells: 56200 nM
Compound 4: middle estimate off by 1.9-fold (0.27 log units), on the low side; the range from low to high includes it.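

In this assay, putting hydrogen in place of chloro on an aromatic carbon gave an 8.7-fold higher number from compound 3 to compound 4 (0.94 log units; beyond the scatter), so toxicity in this test fell on this core too. The change therefore carried over in direction, and the two steps cannot be told apart in size: the same change on two cores in this assay, a 4.8-fold higher number (0.68 log units; beyond the scatter) from compound 1 to compound 2 and an 8.7-fold higher number (0.94 log units; beyond the scatter) from compound 3 to compound 4, 1.8-fold (0.26 log units) apart, within the scatter of two such steps

This shows that the change behaved alike on these two closely related cores, but two pairs cannot show that it would do so on other cores, and they do not explain why the number rises.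

The compounds shown carry only chloro or hydrogen at that carbon. Going by these compounds, what an amine or a methoxy group there would do remains open.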